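The source may hold more compounds than are shown below. What is called first, only, known or untested is meant among the compounds shown, and "the series" means these compounds.

Measured so far in an assay on T47D cells for inhibition of Steryl-sulfatase (Homo sapiens), read by HPLC, with a stated time of 24 h; a higher number here means a weaker inhibitor, a lower number a stronger inhibitor:
compound 1, `Cc1ccccc1N(C)C(=O)c1ccc(-c2ccc(OS(N)(=O)=O)cc2)o1`, gives 28 nM
compound 2, `Cc1c(F)cccc1N(C)C(=O)c1ccc(-c2ccc(OS(N)(=O)=O)cc2)o1`, gives 27 nM

Among the measured compounds shown here, compound 2 stands at the lower of the two numbers, but its only neighbour is compound 1 and the step of a 1.0-fold lower number from compound 1 to compound 2 (0.02 log units; within the scatter) lies within the scatter, so the two compounds cannot be told apart on these data.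

The next compound, compound 3, `Cc1cccnc1N(C)C(=O)c1ccc(-c2ccc(OS(N)(=O)=O)cc2)o1`, differs from compound 2 at the amide-type nitrogen: 3-methylpyridin-2-yl in place of 3-fluoro-2-methylphenyl on an amide-type nitrogen. For the measured compounds named here, the one measured step, a 1.0-fold lower number from compound 1 to compound 2 (0.02 log units; within the scatter), touches the same aryl group on that nitrogen but only exchanges fluoro for hydrogen on an aromatic carbon; it does not exchange the carbon ring for a ring with one hetero atom. Going by the values given here, no measured pair covers that exchange. What the series does show is that a change on this aryl group left this assay unmoved, so the expectation is a step of the same modest kind, with no direction that can be claimed beyond the scatter.

For compound 3 in this assay the estimate is 30 nM, with a range of 10 nM to 90 nM, which is expected to mean a step of a 1.1-fold higher number from compound 2 to compound 3 (0.05 log units; within the scatter).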

Compound 3, half-maximal inhibitory concentration: 1100 nM
For compound 3 the middle estimate is 37-fold (1.56 log units) below the measured one; the whole stated range lies below it.
By their numbers in this assay, from the lowest: compounds 2 and 1 (each within the scatter of the next); then compound 3.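

In this assay the aryl group on the amide-type nitrogen turns out not to be indifferent to change: 3-methylpyridin-2-yl in place of 3-fluoro-2-methylphenyl gives a large loss (a 41-fold higher number from compound 2 to compound 3 (1.61 log units; beyond the scatter)), and in place of 2-methylphenyl the loss is also large (a 39-fold higher number from compound 1 to compound 3 (1.59 log units; beyond the scatter)). Among the compounds shown here, the earlier fluoro-for-hydrogen exchange (a 1.0-fold lower number from compound 1 to compound 2 (0.02 log units; within the scatter)) showed only that this one edit on the carbon ring left the number unmoved, whereas exchanging that carbon ring for a ring with one hetero atom is the first change to go beyond the scatter. Nothing available explains the size of this loss, so it stands as an observation only.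

With a single hetero-atom ring among the compounds shown, it remains open whether any such ring on this nitrogen carries the same loss or whether it is confined to 3-methylpyridin-2-yl. Also open, from the compounds shown here alone, is how a methoxy group or an amine on the 2-methylphenyl ring, or a longer chain in place of the saturated chain carbon on the amide-type nitrogen, would read in this assay against the shared core of compound 1 and compound 2.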